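Trading an Amine Side Chain for Butyl

The source may hold more compounds than are shown below. What is called first, only, known or untested is meant among the compounds shown, and "the series" means these compounds.

In a functional assay on PC-3 cells (Homo sapiens) for antiproliferative activity, read by MTT assay, with a stated time of 72 h (a higher number here means a weaker inhibitor, a lower number a stronger inhibitor), compound 2 `CCn1c(C(=O)NCC(=O)O)ccc1C(CC)(CC)c1ccc(C#CC(O)(CC)CC)c(C)c1` gives 2250 nM and compound 3 `CCN(CC)CCNC(=O)c1cc(C(CC)(CC)c2ccc(C#CC(O)(CC)CC)c(C)c2)cn1CC` gives 5350 nM, so compound 3 holds the higher of these two numbers, by a gap beyond the scatter. Compound 1 `CCCCC(=O)c1ccc(C(CC)(CC)c2ccc(C#CC(O)(CC)CC)c(C)c2)n1CC` reads > 50000 nM, which is a limit of the test and not a number.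

Compound 4 `CCCCC(=O)c1cc(C(CC)(CC)c2ccc(C#CC(O)(CC)CC)c(C)c2)cn1CC` differs from compound 3 by one exchange: butyl in place of (2-(diethylamino)ethyl)amino on a carbonyl carbon. In words, this is butyl in place of (2-(diethylamino)ethyl)amino on a carbonyl carbon.

Within the data shown here, one measured step bears on this change: an at least 22-fold lower number from compound 1 to compound 2 (1.34 log units; beyond the scatter), a large step in which butyl left and (carboxymethyl)amino came in. The exchange now in question runs the other way, with butyl entering, so a higher number, meaning a weaker inhibitor, is expected. The departing group is a different one, however, and the core of compound 1 is not arranged exactly like that of compound 3, so the size carries over only loosely.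

The estimated change is a 5.6-fold higher number from compound 3 to compound 4 (0.75 log units; beyond the scatter). For compound 4 the expected value is 30000 nM, with an estimated range of 9000 nM to 50000 nM.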

Compound 4, half-maximal inhibitory concentration: 48100 nM
Compound 4: middle estimate off by 1.6-fold (0.21 log units), on the low side; the measured number falls inside the stated range.
By their numbers in this assay, from the lowest: compound 2; then compound 3; then compound 4. At a limit, above all of these: compound 1.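

The step gives this exchange a true number at both ends: in this assay, a 9.0-fold higher number from compound 3 to compound 4 (0.95 log units; beyond the scatter). The earlier step, on the core of compound 1, started from a limit, so it could only give a minimum size, whereas this one sizes the change on the core of compound 3. In both steps, the compound with butyl on the carbonyl carbon holds the higher number, and neither step goes against this, though two steps make only a small pattern, and compound 4 leaves little room before the top of the test: the limit of > 50000 nM in this assay, at which 1 of the 4 values shown sits.

Going by these compounds, it remains open which part of the (2-(diethylamino)ethyl)amino group carries the difference. A simple ethylamino group or a carboxylic acid at the end of the same chain, placed on this carbonyl carbon, would help separate the amide hydrogen from the diethylamino end.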